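This account rests on a few compounds, and the source may have more. Where it says the series, first, only, none or still open, it means among the compounds named here.

Working notes on the series in a functional assay on KB cells (Homo sapiens) for cytotoxicity, read by sulforhodamine B assay; a higher number here means a weaker inhibitor, a lower number a stronger inhibitor. Compound 1 (`C=C1[C@@H](OC(C)=O)C[C@@H]2[C@](C)(COC=O)[C@H](OC(C)=O)CC[C@@]2(C)[C@@H]1C[C@@H](Nc1ccccc1F)C1=CCOC1=O`) gives 29000 nM, compound 3 (`C=C1[C@@H](C/C=C2/C(=O)OC[C@H]2OC(C)=O)[C@]2(C)CC[C@@H](OC(C)=O)[C@@](C)(CO[Si](C)(C)C(C)(C)C)[C@H]2C[C@@H]1O`) gives 9790 nM, and compound 2 (`C=C1[C@@H](OC(C)=O)C[C@@H]2[C@](C)(CO[Si](C)(C)C(C)(C)C)[C@H](OC(C)=O)CC[C@@]2(C)[C@@H]1C[C@@H](Nc1ccccc1F)C1=CCOC1=O`) gives 4740 nM, the lowest number of the three.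

Compound 4 (`C=C1[C@@H](OC(C)=O)C[C@@H]2[C@](C)(CO[Si](C)(C)C(C)(C)C)[C@H](OC(C)=O)CC[C@@]2(C)[C@@H]1C[C@@H](Nc1cccc(OC)c1)C1=CCOC1=O`) keeps the core of compound 2 and changes one group on an amine nitrogen: 3-methoxyphenyl in place of 2-fluorophenyl on an amine nitrogen.

Within the data shown here, no measured step touches this amine nitrogen. Among the measured compounds shown here, the only single-place step available, a 6.1-fold lower number from compound 1 to compound 2 (0.79 log units; beyond the scatter), lies at an oxygen on a saturated carbon elsewhere in the molecule. It therefore serves only as a rough gauge of how far one group can move the numbers in this small set, and it gives no direction for the new change. Compound 3 lacks an aryl amine altogether and adds nothing on this point.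

The estimated step, a 1.1-fold lower number from compound 2 to compound 4 (0.02 log units; within the scatter), is expected to stay no larger than that gauge, with no preferred direction. For compound 4 the expected value in this assay is 4500 nM, with an estimated range of 1500 nM to 13000 nM.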

Compound 4, half-maximal inhibitory concentration: 45200 nM
Compound 4: the middle estimate sits 10-fold (1.00 log units) below what was measured; measured number outside the range, above it.
By their numbers in this assay, from the lowest: compound 2; then compound 3; then compounds 1 and 4 (each within the scatter of the next).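

In this assay, the group on the amine nitrogen proves able to shift the number: 3-methoxyphenyl in place of 2-fluorophenyl gives a 9.5-fold higher number from compound 2 to compound 4 (0.98 log units; beyond the scatter) with the rest of the molecule unchanged. Among these compounds, this is the first measured step at this nitrogen, and it runs upward, whereas the only earlier single-place step, a 6.1-fold lower number from compound 1 to compound 2 (0.79 log units; beyond the scatter), at an oxygen on a saturated carbon, runs downward. No measurement here accounts for the rise.

As far as these compounds go, how an unsubstituted phenyl, a 3-fluorophenyl or a 2-methoxyphenyl group would read on this nitrogen stays open, so the parts played by losing the fluorine and gaining the methoxy group cannot be separated. From the compounds shown here alone, whether the same exchange gives a similar step on the core of compound 1 also remains open.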